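Aryl Swap on the Ketone Side Chain: Cytotoxicity Notes

This account rests on a few compounds, and the source may have more. Where it says the series, first, only, none or still open, it means among the compounds named here.

Measured in a functional assay on A549 cells (Homo sapiens) for cytotoxicity, read by MTT assay, with a stated time of 48 h; a lower number here means a stronger inhibitor, a higher number a weaker inhibitor:
compound 1 `C#CCSc1nnc(-c2cc(OC)c(OC)c(OC)c2)n1N1C(=O)c2ccccc2C1=O` — > 200000 nM
compound 2 `COc1cc(-c2nnc(SCc3ccccc3)n2N2C(=O)c3ccccc3C2=O)cc(OC)c1OC` — > 200000 nM
compound 3 `COc1ccc(C(=O)CSc2nnc(-c3cc(OC)c(OC)c(OC)c3)n2N2C(=O)c3ccccc3C2=O)cc1` — 30000 nM

Compound 1 gives only a limit of the assay. So does compound 2. Both limits are the same one, (the limit of > 200000 nM in this assay, at which 2 of the 3 values shown sit). Going by the values given here, compound 3 is the only one of the three with a real number in this assay, so the series so far stands on a single point.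

an at least 6.6-fold lower number from compound 1 to compound 3 (0.82 log units; beyond the scatter) and an at least 6.6-fold lower number from compound 2 to compound 3 (0.82 log units; beyond the scatter) both accompany the entry of the (4-methoxyphenyl)carbonyl group on the saturated chain carbon bound to a sulfur, and both read as steps of at least modest size toward a lower number.

Compound 4 `COc1cc(-c2nnc(SCC(=O)c3ccc(F)c(F)c3)n2N2C(=O)c3ccccc3C2=O)cc(OC)c1OC` keeps that carbonyl and changes only the aryl group sitting on it: 3,4-difluorophenyl in place of 4-methoxyphenyl on a carbonyl carbon. Among the compounds with values here, no measured step in this set alters the aryl group on the carbonyl carbon; the two existing steps replace the whole group on the chain carbon. Since the carbonyl that both measured steps brought in is retained, compound 4 is expected to stay close to compound 3, and no change at the digits printed from compound 3 to compound 4 (within the scatter) is expected to lie within the scatter. Compound 4 is therefore estimated at 30000 nM, between 10000 nM and 100000 nM, in this assay.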

Compound 4, half-maximal inhibitory concentration: > 200000 nM
Compound 4: no number, only a limit; the forecaster's own chance of this, stated with the estimate: 25%; at least 6.6-fold (0.82 log units) between middle value and limit.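

The earlier steps shown here replaced the whole group on the saturated chain carbon, so they could not separate the carbonyl from the aryl group it carries; this step does, with the carbonyl kept and 3,4-difluorophenyl in place of 4-methoxyphenyl on the carbonyl carbon giving an at least 6.6-fold higher number from compound 3 to compound 4 (0.82 log units; beyond the scatter) in this assay. Going by these compounds alone, the carbonyl alone therefore does not go with a measurable value in this set, with compound 3 the only member that has one and compound 4 the compound that goes against any reading based on the carbonyl alone. Compound 4 gives a limit and not a number, the same limit as compounds 1 and 2, and the steps joining it to those two compounds cannot be read: the limit of > 200000 nM in this assay, at which 3 of the 4 values shown sit.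

The compounds shown leave open whether the methoxy group on the aryl ring or the two fluorine atoms decide the outcome, and how far the value of compound 4 lies past its limit. A plain phenyl, a 4-hydroxyphenyl or a 4-aminophenyl on the carbonyl carbon would bear on the first question, and any of them would test whether compound 3 stays a lone point.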